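The source may hold more compounds than are shown below. What is called first, only, known or untested is meant among the compounds shown, and "the series" means these compounds.

Measured in a functional assay on COLO 205 cells (Homo sapiens) for inhibition, read by sulforhodamine B assay; on this read-out higher numbers stand for weaker inhibition of growth and lower numbers for stronger inhibition of growth:
- compound 1 `FC(F)(F)c1ccc(-c2ccc(-c3ccc(-c4nc5ccccc5[nH]4)cc3)cc2)cc1`: 33900 nM
- compound 2 `Oc1ccc(-c2ccc(-c3ccc(-c4nc5ccccc5[nH]4)cc3)cc2)cc1`: 100000 nM
- compound 3 `Clc1cccc(-c2ccc(-c3ccc(-c4nc5ccccc5[nH]4)cc3)cc2)c1`: 100000 nM

Compound 1 has the lowest number of the three. The measured steps away from it are modest but beyond the scatter: a 2.9-fold higher number from compound 1 to compound 2 (0.47 log units; beyond the scatter) and a 2.9-fold higher number from compound 1 to compound 3 (0.47 log units; beyond the scatter). Between the other two, the result is no change at the digits printed from compound 2 to compound 3 (within the scatter).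

The next compound, compound 4 `Oc1cccc2[nH]c(-c3ccc(-c4ccc(-c5ccc(C(F)(F)F)cc5)cc4)cc3)nc12`, retains the 4-(trifluoromethyl)phenyl group of compound 1 and carries hydroxy in place of hydrogen on an aromatic carbon, turning 1H-benzimidazol-2-yl into 4-hydroxy-1H-benzimidazol-2-yl (hydroxy in place of hydrogen on an aromatic carbon). Among the measured compounds shown here, no measured step changes this place, so the evidence is indirect. The closest comparison is a 2.9-fold higher number from compound 1 to compound 2 (0.47 log units; beyond the scatter), where hydroxy also enters, but in place of trifluoromethyl and at a different place. The change to compound 3 says nothing about this place. These data therefore support only a loose expectation of a small rise in the number, and no change cannot be excluded. The expected step in this assay is a 1.3-fold higher number from compound 1 to compound 4 (0.12 log units; within the scatter), an estimate of modest size. For compound 4 the estimated value is 45000 nM, with an expected range of 12000 nM to 100000 nM.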

Compound 4, concentration for 50% growth inhibition: 3410 nM
Compound 4: middle estimate off by 13-fold (1.12 log units), on the high side, and the stated range ends above it.
By their numbers in this assay, from the lowest: compound 4; then compound 1; then compounds 2 and 3 (each within the scatter of the next).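

In this assay, hydroxy in place of hydrogen on an aromatic carbon, turning 1H-benzimidazol-2-yl into 4-hydroxy-1H-benzimidazol-2-yl, gives a 9.9-fold lower number from compound 1 to compound 4 (1.00 log units; beyond the scatter) and is the only step shown at this position, since compounds 1, 2 and 3 all carry the unsubstituted 1H-benzimidazol-2-yl and differ elsewhere. The entry of hydroxy therefore does not have one direction across the series: here the number falls, whereas hydroxy in place of trifluoromethyl gives a 2.9-fold higher number from compound 1 to compound 2 (0.47 log units; beyond the scatter) and differs in both the place and the group it replaces. No measurement on these compounds bears on why the step at this position takes this direction or size.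

On these data alone, it remains open whether the lower number depends on hydroxy itself or would also follow from a methoxy group, an amine or a fluorine atom at the same place on the 4-hydroxy-1H-benzimidazol-2-yl position. Also open, as far as these compounds go, is whether the same change carries over when 4-hydroxyphenyl or 3-chlorophenyl stands in place of 4-(trifluoromethyl)phenyl, as in compounds 2 and 3.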